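The source may hold more compounds than are shown below. What is called first, only, known or untested is meant among the compounds shown, and "the series" means these compounds.

Measured so far:
compound 1 `CNC(=N)c1cccc(/C(C)=C(/F)C(=O)Nc2ccc(-c3ccncc3S(N)(=O)=O)cc2)c1`, 4.3 L/kg
compound 2 `CN(C)c1nccc2ccc(/C=C\C(=O)Nc3ccc(-c4ccccc4S(N)(=O)=O)cc3)cc12`, 7.4 L/kg
compound 3 `C/C(=C(\F)C(=O)Nc1ccc(-c2ccccc2S(N)(=O)=O)cc1F)c1ccc2ccnc(N)c2c1`, 3.7 L/kg

In an in vivo ADME assay on the whole organism with Rattus norvegicus as the target (on this read-out lower numbers stand for narrower distribution and higher numbers for wider distribution into tissues), compound 3 gives 3.7 L/kg. Among the measured compounds shown here, its number sits within the usual scatter of both compound 1 and compound 2, so the three measured values separate no compound from another on this read-out.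

Compound 4 `C/C(=C(\F)C(=O)Nc1ccc(-c2ccccc2S(N)(=O)=O)cc1Br)c1ccc2ccnc(N)c2c1` is the next entry: bromo in place of fluoro on an aromatic carbon. For the measured compounds named here, no measured pair shows this change, so nothing on file tells its size. Given that compound 1, compound 2 and compound 3 all fall within the scatter of each other, the step of a 1.1-fold higher number from compound 3 to compound 4 (0.03 log units; within the scatter) is expected to stay within the scatter, with no clear direction. Compound 4 is therefore estimated at 4 L/kg, in the range 2 L/kg to 8 L/kg.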

Compound 4, volume of distribution: 0.61 L/kg
Estimate against measurement, compound 4: 6.6-fold (0.82 log units) above; the whole stated range lies above it.
By their numbers in this assay, from the lowest: compound 4; then compounds 3, 1 and 2 (each within the scatter of the next).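

In this assay, bromo in place of fluoro on this aromatic carbon, ortho to a large group, gives a 6.1-fold lower number from compound 3 to compound 4 (0.78 log units; beyond the scatter). One heavy atom replaces one heavy atom, with no hydrogen-bond donor, acceptor or net charge entering or leaving, yet the number moves beyond the scatter, so this position responds to the choice of halogen. No measurement on file bears on the reason for this step.

As far as these compounds go, whether the lower number is particular to bromo remains open, as chloro, methyl or nitrile on this carbon would show. A single step also cannot tell whether the same exchange carries over to the cores of compound 1 and compound 2.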